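Amidoxime series: nitrogen substituent change from compound 1

The compounds below may be only part of what the source reports. "The series", "measured", "known", "first", "only" and "open" are said of these compounds alone.

Compound 1 `O/N=C(/Nc1ccccc1)c1ccc2occc2c1` — in an assay on tissue (HeLa cells) for inhibition of Indoleamine 2,3-dioxygenase 1 (Homo sapiens), read by spectrophotometry (a higher number here means a weaker inhibitor, a lower number a stronger inhibitor), compound 1 gives 19000 nM.
Compound 2 `CC1CCN(C(=O)c2cccc(N/C(=N/O)c3ccc4occc4c3)c2)CC1` — in this assay compound 2 gives > 30000 nM, a limit of the assay and not a number.
Compound 3 `O/N=C(/Nc1cccc(COc2ccccc2)c1)c1ccc2occc2c1` — in this assay compound 3 gives > 30000 nM, a limit of the assay and not a number.

Among the measured compounds shown here, compound 1 is the only member of the series with a numerical value in this assay; the other two values sit at the limit of > 30000 nM in this assay, at which 2 of the 3 values shown sit. Both measured steps start from compound 1: an at least 1.5-fold higher number from compound 1 to compound 2 (0.19 log units; that floor lies within the scatter) and an at least 1.5-fold higher number from compound 1 to compound 3 (0.19 log units; that floor lies within the scatter). Between the two limit compounds there is a step that the two limits leave unreadable from compound 2 to compound 3.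

Compound 4 `O/N=C(/NCC1CC1)c1ccc2occc2c1` differs from compound 1 by cyclopropylmethyl in place of phenyl on an amine nitrogen. Neither measured step touches this nitrogen; both add a group to an aromatic carbon of the phenyl that compound 4 no longer carries, so they bear on the new step only in showing that the series has so far stayed at weak inhibition or beyond the limit. For compound 4 no change beyond the scatter in this assay is expected: a 1.3-fold higher number from compound 1 to compound 4 (0.12 log units; within the scatter). Compound 4 is estimated at 25000 nM, with a range from 8000 nM to 80000 nM, and with a real chance that this assay returns only a limit.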

Compound 4, half-maximal inhibitory concentration: > 30000 nM
Compound 4: a limit, no number; the forecaster's own chance of this, stated with the estimate: 40%; at least 1.2-fold (0.07 log units) between middle value and limit.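

Among the compounds shown, compound 4 is the only one changed on the amine nitrogen itself, where the earlier steps changed only an aromatic carbon of the phenyl. In this assay compound 4 gives > 30000 nM, a limit of the assay and not a number. The step reads an at least 1.5-fold higher number from compound 1 to compound 4 (0.19 log units; that floor lies within the scatter), so cyclopropylmethyl in place of phenyl on an amine nitrogen gives no sign of a stronger inhibitor, while the size of any loss stays unknown, and compound 1 remains the only compound in the series with a number: the limit of > 30000 nM in this assay, at which 3 of the 4 values shown sit.

The compounds shown leave open whether any substituent on this nitrogen can give a stronger inhibitor than compound 1, for example a benzyl group, which keeps an aromatic ring, or a pyridyl ring in place of phenyl. Going by these compounds, it also remains open whether a small group on the phenyl of compound 1, such as a fluorine or a methoxy, would change the value beyond the scatter, since the larger groups on compounds 2 and 3 give only limits.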